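Trimming the amide aryl group down to methylsulfanyl

This account rests on a few compounds, and the source may have more. Where it says the series, first, only, none or still open, it means among the compounds named here.

Compound 1 `O=C(Nc1ccc(Cl)cn1)C1CCCN(C(=O)c2cc(C(F)(F)F)cc(C(F)(F)F)c2)C1` and compound 2 `COC(=O)c1cc(-c2cccc(NC(=O)C3CCCN(C(=O)c4cc(C(F)(F)F)cc(C(F)(F)F)c4)C3)c2)co1` share a core and both show no inhibition in an ADME assay on PC-3 cells (Homo sapiens) for cytotoxicity, read by WST assay, tested at 100 uM; on this read-out higher numbers stand for more inhibition at the one concentration tested (going by the name of the read-out) and lower numbers for less inhibition: compound 1 gives 0% and compound 2 gives 0%, level with compound 1 within the scatter. Compound 3 `CSc1cccc(NC(=O)C2CCCN(C(=O)c3cc(C(F)(F)F)cc(C(F)(F)F)c3)C2)c1` differs from compound 2 by methylsulfanyl in place of 5-(methoxycarbonyl)furan-3-yl on an aromatic carbon. Within the data shown here, no measured pair shows a change of this kind, so the step is expected to be no change at the digits printed from compound 2 to compound 3 (within the scatter), none beyond the scatter. Compound 3 is therefore estimated to give 0% in this assay, within 0% to 12%.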

Compound 3, a percentage reported as inhibition, at one concentration (the size of the read-out at that concentration, not a potency): 0%
For compound 3 middle estimate and measured number coincide at the digits printed; the measured number falls inside the stated range.
By their numbers in this assay, from the lowest: compounds 1, 2 and 3 (each within the scatter of the next).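

In this assay, putting methylsulfanyl in place of 5-(methoxycarbonyl)furan-3-yl on an aromatic carbon gives no change at the digits printed from compound 2 to compound 3 (within the scatter), so removing this ring-bearing group leaves the read-out unmoved. With 3-(methylsulfanyl)phenyl in place of 5-chloropyridin-2-yl on an amide-type nitrogen, the result is likewise no change at the digits printed from compound 1 to compound 3 (within the scatter). No supporting data bear on this result.

All of the changes shown end at the same reading, so they do not tell whether any group at this position can raise it. An amine or a carboxylic acid on this aromatic carbon remains an open case.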